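From compound 1 to its 4-chlorophenyl relative

The compounds below may be only part of what the source reports. "The series", "measured", "known", "first", "only" and "open" are said of these compounds alone.

Measured so far in a functional assay on MCF7 cells (Homo sapiens) for cytotoxicity, read by MTT assay, with a stated time of 72 h; on this read-out lower numbers stand for stronger inhibition and higher numbers for weaker inhibition
- compound 1 `CCOC(=O)C1=C(C)NC(=S)NC1c1cn(C(=O)CNc2ccccc2)c2ccccc12` gives 52 ug/mL
- compound 2 `CCOC(=O)C1=C(C)NC(=O)NC1c1cn(C(=O)CNc2ccc([N+](=O)[O-])cc2C)c2ccccc12` gives 50 ug/mL

Going by the values given here, the numbers for compound 1 and compound 2 lie within the usual scatter of each other, so compound 1 stands level with the only other compound measured. Compound 3 `CCOC(=O)C1=C(C)NC(=S)NC1c1cn(C(=O)CNc2ccc(Cl)cc2)c2ccccc12` comes from compound 1 through one change chloro in place of hydrogen on an aromatic carbon with chloro in place of hydrogen on an aromatic carbon, para to a large group, so phenyl becomes 4-chlorophenyl. Among the compounds with values here, no measured pair shows what this change does. The expected move is modest, towards stronger inhibition in this assay and possibly no larger than the scatter, with a 1.5-fold lower number from compound 1 to compound 3 (0.17 log units; within the scatter) as the estimated step. For compound 3 the estimated value is 35 ug/mL with an expected range of 12 ug/mL to 75 ug/mL until it is measured.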

Compound 3, half-maximal inhibitory concentration: 80 ug/mL
Beside the measured number, compound 3's estimate is 2.3-fold (0.36 log units) below it, outside the stated range (above it).
By their numbers in this assay, from the lowest: compounds 2, 1 and 3 (each within the scatter of the next).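

In this assay, chloro on the aromatic carbon para to a large group gives a 1.5-fold higher number from compound 1 to compound 3 (0.19 log units; within the scatter) and so leaves the two compounds level. Going by these compounds alone, this is the first pair that differs in one place, and it shows that turning phenyl into 4-chlorophenyl brings no gain in strength here. No measurement shown speaks to the reason for this result. Still open, as far as these compounds go, is whether a different group at this place, such as methoxy or a carboxylic acid, would give a step beyond the scatter.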